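Shifting Carbons from the Linker to the Piperazine

The source may report more compounds than this note shows. Statements on the series, on what has been measured and on what is new or still open speak of the compounds shown alone.

Measured compounds:
- compound 1 `CN1CCN(CCCCCCn2c3c(c4ccccc42)C(=O)c2c[n+]([O-])c4ccccc4c2C3=O)CC1`: in a functional assay on MDA-MB-231 cells (Homo sapiens) for cytotoxicity, read by MTT assay, with a stated time of 72 h (on this read-out lower numbers stand for stronger inhibition and higher numbers for weaker inhibition), compound 1 gives 2400 nM
- compound 2 `O=C1c2c[n+]([O-])c3ccccc3c2C(=O)c2c1c1ccccc1n2Cc1cn([C@H]2C[C@H](O)[C@@H](CO)O2)nn1`: in this assay compound 2 gives 580 nM
- compound 3 `CC1(C)OCC(Cn2cc(Cn3c4c(c5ccccc53)C(=O)c3c[n+]([O-])c5ccccc5c3C4=O)nn2)O1`: in this assay compound 3 gives 230 nM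

Among these three, compound 1 stands at the highest number, that is, the weakest inhibition; compound 2 lies nearer to it and compound 3 furthest away, both gaps beyond the scatter. All three share the same core and differ only in the group carried on the aromatic nitrogen.

Compound 4 `CCCCN1CCN(CCCCn2c3c(c4ccccc42)C(=O)c2c[n+]([O-])c4ccccc4c2C3=O)CC1` is the next candidate. Its difference from compound 1 is 4-butylpiperazin-1-yl in place of 2-(4-methylpiperazin-1-yl)ethyl on a saturated chain carbon, four bonds along the chain from an aromatic nitrogen. In plain terms, two chain carbons move out of the linker and onto the far nitrogen of the piperazine, so the overall size and the count of donors and acceptors are nearly unchanged.

Going by the values given here, the one measured step, a 2.5-fold lower number from compound 2 to compound 3 (0.40 log units; beyond the scatter), concerns a quite different kind of substituent on the aromatic nitrogen and says nothing about lengthening or shortening a piperazine-bearing chain. Among the compounds with values here, no measured pair therefore bears directly on the move from compound 1 to compound 4, and a step within the scatter of this assay is the most reasonable expectation, with the direction open.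

On that basis compound 4 is estimated at 2000 nM, with a range from 700 nM to 6000 nM, corresponding to an expected step of a 1.2-fold lower number from compound 1 to compound 4 (0.08 log units; within the scatter).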

Compound 4, half-maximal inhibitory concentration: 900 nM
Beside the measured number, compound 4's estimate is 2.2-fold (0.35 log units) above it, and the stated range covers the measured number.
By their numbers in this assay, from the lowest: compound 3; then compounds 2 and 4 (each within the scatter of the next); then compound 1.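

In this assay, the change on this saturated chain carbon, four bonds along the chain from an aromatic nitrogen, gives a 2.7-fold lower number from compound 1 to compound 4 (0.43 log units; beyond the scatter). Going by these compounds alone, this is the first measured step between two compounds that both carry a piperazine, and it shows that rearranging the chain carbons around that ring can move the number beyond the scatter, even though the ring type and the counts of hydrogen-bond donors and acceptors stay the same in 4-butylpiperazin-1-yl and 2-(4-methylpiperazin-1-yl)ethyl. No measurement shown here accounts for the size or direction of this step.

The step combines a shorter linker with a longer group on the far piperazine nitrogen, so these compounds leave open how much each part contributes; a compound with the shorter linker and the 4-methylpiperazin-1-yl group would help to separate the two. From the compounds shown here alone, it also remains open whether the piperazine itself matters, a question that a morpholine ring or a simple dimethylamine at the end of the same chain could address.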